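The source may report more compounds than this note shows. Statements on the series, on what has been measured and on what is new or still open speak of the compounds shown alone.

For the measured compounds named here, compound 2 `CC#C[C@@H](CC(=O)O)c1ccc(OC[C@H]2COc3ccc(OC(C)C)cc3O2)cc1` gives 280 nM in a functional assay on HEK293 cells for agonist activity at Free fatty acid receptor 1 (Homo sapiens), read by fluorescence and calcium flux, with a stated time of 10 min (on this read-out higher numbers stand for an effect only at larger amounts of compound and lower numbers for an effect already at smaller amounts), the highest of the two numbers known so far; its nearest neighbour is compound 1 `CC#C[C@@H](CC(=O)O)c1ccc(OC[C@H]2COc3ccc(Br)cc3O2)cc1`, which gives 210 nM in this assay. Going by the values given here, the only measured step, a 1.3-fold higher number from compound 1 to compound 2 (0.12 log units; within the scatter), stayed within the scatter. Compound 3 `CC#C[C@@H](CC(=O)O)c1ccc(OC[C@H]2COc3ccc(CO)cc3O2)cc1` differs from compound 2 by hydroxymethyl in place of isopropoxy on an aromatic carbon. Among the compounds with values here, no measured step touches a hydroxymethyl group, so the one exchange at this position is the only guide, and it suggests no shift beyond the scatter. Compound 3 is therefore expected to give about 320 nM in this assay, between 120 nM and 850 nM, an expected step of a 1.1-fold higher number from compound 2 to compound 3 (0.06 log units; within the scatter).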

Compound 3, half-maximal effective concentration: > 30000 nM
Compound 3: no number, only a limit; the forecaster's own chance of this, stated with the estimate: 5%; middle value at least 93-fold (1.97 log units) from the limit.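

The value of compound 3 in this assay is a limit, not a number: the limit of > 30000 nM in this assay, at which 1 of the 3 values shown sits. The position is therefore not indifferent to what it carries, although bromo and isopropoxy stayed within the scatter of each other: the exchange for hydroxymethyl gives an at least 100-fold higher number from compound 2 to compound 3 (2.02 log units; beyond the scatter) and an at least 140-fold higher number from compound 1 to compound 3 (2.15 log units; beyond the scatter). Unlike isopropoxy, hydroxymethyl carries a hydrogen-bond donor and has fewer heavy atoms. The compounds shown do not separate these two differences. As far as these compounds go, how a methoxymethyl group, an aminomethyl group or a carboxylic acid would behave at this position remains open.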